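A few compounds are considered here, and "the series" means these few. Any claim that something is new, unique, unknown or untested is made for them only; others in the source may bear on it.

Measured compounds:
compound 1 `O=C(CSc1nnc(-c2ccncc2)o1)N/N=C/c1ccccc1`, 22100 nM
compound 2 `O=C(CSc1nnc(-c2ccncc2)o1)N/N=C/c1ccc(Cl)cc1`, 20500 nM
compound 3 `O=C(CSc1nnc(-c2ccncc2)o1)N/N=C/c1ccc([N+](=O)[O-])cc1`, 31500 nM

These three share a common core and differ only in the group on the carbon with a double bond to nitrogen. In a functional assay on BGC-823 cells (Homo sapiens) for cytotoxicity, read by MTT assay, with a stated time of 48 h (on this read-out lower numbers stand for stronger inhibition and higher numbers for weaker inhibition), compound 3 gives the highest of the three numbers, yet its nearest neighbour is compound 1 and its furthest is compound 2, and both of those gaps sit within the scatter, so no ordering among the three can be read from them.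

Compound 4 `O=C(CSc1nnc(-c2ccncc2)o1)N/N=C/c1ccccc1F` has not been measured. Its difference from compound 3 is 2-fluorophenyl in place of 4-nitrophenyl on a carbon with a double bond to nitrogen. Going by the values given here, no measured step swaps one aromatic substituent pattern for another in this way; the steps that come closest are a 1.4-fold higher number from compound 1 to compound 3 (0.15 log units; within the scatter) and a 1.5-fold higher number from compound 2 to compound 3 (0.19 log units; within the scatter), since both remove or add the nitro group, and both stayed within the scatter, as did a 1.1-fold lower number from compound 1 to compound 2 (0.03 log units; within the scatter). Nothing in the measured series therefore points to a step beyond the scatter for this assay, in either direction. Compound 4 is expected to give 22000 nM, with a range from 12000 nM to 40000 nM, which corresponds to an expected 1.4-fold lower number from compound 3 to compound 4 (0.16 log units; within the scatter).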

Compound 4, half-maximal inhibitory concentration: 24000 nM
Compound 4: the middle estimate sits 1.1-fold (0.04 log units) below what was measured; measured number inside the range.
By their numbers in this assay, from the lowest: compounds 2, 1, 4 and 3 (each within the scatter of the next).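

In this assay, going by these compounds alone, a fluoro group on the ring, placed differently from the chloro and nitro groups of the earlier compounds, still produces no step beyond the scatter (a 1.1-fold higher number from compound 1 to compound 4 (0.04 log units; within the scatter)). The same holds against both substituted compounds (a 1.2-fold higher number from compound 2 to compound 4 (0.07 log units; within the scatter)) and (a 1.3-fold lower number from compound 3 to compound 4 (0.12 log units; within the scatter)), so phenyl, 4-chlorophenyl, 4-nitrophenyl and 2-fluorophenyl on the carbon with a double bond to nitrogen cannot be told apart on this read-out. No supporting data are available to explain why these four groups cannot be separated.

The compounds shown leave open whether a ring carrying an amine or a carboxylic acid, or a saturated ring or alkyl chain in place of the aromatic ring, would move the number beyond the scatter. They also leave open whether changes elsewhere on the shared core would do so.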